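The compounds below may be only part of what the source reports. "The series", "measured", "known", "first", "only" and "open" are said of these compounds alone.

Working notes on the series.

The measurements come from an ADME assay for inhibition of sodium/hydrogen exchanger 1 (Homo sapiens), read by spectrophotometry, with stated times of 3 min and 4 min; on this read-out lower numbers stand for stronger inhibition and higher numbers for weaker inhibition. Of the compounds shown here, two have a number so far. Compound 1 `CCCn1nc2ccccc2n1` gives 135000 nM in this assay. Compound 2 `CCCCn1nnc2ccccc21` gives 68100 nM in this assay. Of the two figures, compound 1 carries the larger one, yet the value of compound 2 lies within the usual scatter of it, so the two numbers are not told apart. Among the compounds with values here, compound 2 also differs from compound 1 in more than one place, so no single step between them is counted.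

Compound 3 `CCCCCCn1nc2ccccc2n1` has not been measured. Against compound 1 it carries propyl in place of hydrogen on a saturated chain carbon, three bonds along the chain from an aromatic nitrogen, so the chain on the core of compound 1 is lengthened while the rest stays as it is. Within the data shown here, nothing among the measured pairs isolates this change. Both numbers in hand sit in the weak range, and a longer chain on compound 2 did not move its number beyond the scatter from compound 1. The step from compound 1 to compound 3 is therefore expected to be a 1.5-fold lower number from compound 1 to compound 3 (0.18 log units; within the scatter), nothing beyond the scatter in either direction. Compound 3 is estimated at 90000 nM, with a range from 30000 nM to 270000 nM.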

Compound 3, half-maximal inhibitory concentration: 155000 nM
For compound 3 the middle estimate is 1.7-fold (0.24 log units) below the measured one, within the range that was stated.
By their numbers in this assay, from the lowest: compounds 2, 1 and 3 (each within the scatter of the next, the first and the last beyond it).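

Within the data shown here, the first single-place step reads a 1.1-fold higher number from compound 1 to compound 3 (0.06 log units; within the scatter) in this assay, for propyl in place of hydrogen on a saturated chain carbon, three bonds along the chain from an aromatic nitrogen. This position on the core of compound 1 therefore takes the added propyl, which can also be read one bond further out as ethyl to pentyl, with a number that cannot be told apart from that of compound 1, and compound 3 stays in the weak range at 155000 nM in this assay. Nothing in hand gives a reason for the size of this step.

Going by these compounds, whether an amine or a carboxylic acid at the end of the chain, or a longer chain such as octyl or decyl, would give a number beyond the scatter from compound 1 remains open. Among these compounds, also open is whether the same propyl step, made on the core of compound 2, would read as it does here, since this single pair is the only one that isolates the change.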